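Swapping the aniline ring on a macrocyclic-amine quinazoline series

This account rests on a few compounds, and the source may have more. Where it says the series, first, only, none or still open, it means among the compounds named here.

Measured compounds:
compound 1 `COc1cc2ncnc(Nc3cccc(Cl)c3)c2cc1OCCCN1CCNCCNCCNCC1`: 1420 nM
compound 2 `COc1cccc(Nc2ncnc3cc(OC)c(OCCCN4CCNCCNCCNCC4)cc23)c1`: 3210 nM
compound 3 `COc1cc2ncnc(Nc3cccc(Br)c3)c2cc1OCCCN1CCNCCNCC1`: 2320 nM

All three share one core and differ only in the substituted aniline or in the size of the ring on the chain. In a functional assay on A-431 cells (Homo sapiens) for antiproliferative activity, read by MTT assay, with a stated time of 72 h (a higher number here means a weaker inhibitor, a lower number a stronger inhibitor), compound 3 gives 2320 nM, which places it second highest of the three numbers; its gaps to compound 2 and to compound 1 both lie within the usual scatter, so no order among these three can be read from compound 3 alone.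

Compound 4 `COc1cc2ncnc(Nc3ccc(C#N)cc3F)c2cc1OCCCN1CCNCCNCC1` is not yet measured. It carries the change (4-cyano-2-fluorophenyl in place of 3-bromophenyl on a nitrogen on an aromatic ring). Going by the values given here, the only measured step that touches the same part of the molecule is a 2.3-fold higher number from compound 1 to compound 2 (0.35 log units; beyond the scatter), a modest weakening when the halogen was replaced. Compound 4 also loses its halogen at that position and gains a different substitution pattern, so a modest weakening is expected in this assay, though a larger one cannot be excluded given how different the entering group is.

For compound 4 the expected step is a 2.4-fold higher number from compound 3 to compound 4 (0.37 log units; beyond the scatter), giving an estimate of 5500 nM with a range from 2000 nM to 16000 nM.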

Compound 4, half-maximal inhibitory concentration: 12700 nM
The estimate for compound 4 lay 2.3-fold (0.36 log units) below the measured number; the measured number falls inside the stated range.
By their numbers in this assay, from the lowest: compounds 1, 3 and 2 (each within the scatter of the next, the first and the last beyond it); then compound 4.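

In this assay, exchanging 3-bromophenyl for 4-cyano-2-fluorophenyl on the nitrogen gives a 5.5-fold higher number from compound 3 to compound 4 (0.74 log units; beyond the scatter), so the choice of aniline ring can clearly weaken a compound while the rest of the molecule stays the same. Going by these compounds alone, this step is larger than a 2.3-fold higher number from compound 1 to compound 2 (0.35 log units; beyond the scatter), the only earlier step that swapped a group on the aniline ring, which shows that this position can respond more strongly than that first swap suggested. The change is also several changes at once: the bromine leaves, while a nitrile and a fluorine enter and the pattern of substitution shifts, so the loss belongs to the whole swap and not to any single atom.

As far as these compounds go, whether the nitrile, the fluorine or the loss of the bromine matters most stays open, as does how an aniline ring bearing an amine or a carboxylic acid would behave here. No measured property is available to explain the loss.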